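The source may report more compounds than this note shows. Statements on the series, on what has been measured and on what is new or still open speak of the compounds shown alone.

Compound 1 (`C#CCSc1nc(Nc2ccc(C)cc2)c2ccncc2n1`) gives 6170 nM
Compound 2 (`C#CCSc1nc(Nc2cccc(OC)c2)c2ccncc2n1`) gives 920 nM

Both compounds were tested in a functional assay on HepG2 cells (Homo sapiens) for inhibition, read by MTT assay, with a stated time of 72 h (on this read-out lower numbers stand for stronger inhibition and higher numbers for weaker inhibition), and compound 2 holds the lower of the two numbers, with a gap to compound 1 that lies beyond the usual scatter. Compound 3 (`C#CCSc1nc(Nc2cccc(O)c2)c2ccncc2n1`) has hydrogen in place of methyl on an oxygen on an aromatic ring, which reads as methoxy to hydroxy (hydrogen in place of methyl on an oxygen on an aromatic ring). Within the data shown here, no pair of measured compounds shows this change on its own, so the expectation starts from compound 2 at 920 nM and has little else to rest on. In this assay a modest step towards a higher number is expected, possibly not much beyond the scatter. The estimate amounts to a step (a 1.6-fold higher number from compound 2 to compound 3 (0.21 log units; within the scatter)). For compound 3 the expected value is 1500 nM (estimated range 400 nM to 5500 nM).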

Compound 3, half-maximal inhibitory concentration: 29500 nM
Compound 3: middle estimate off by 20-fold (1.29 log units), on the low side, and the stated range ends below it.
By their numbers in this assay, from the lowest: compound 2; then compound 1; then compound 3.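

In this assay, the change from methoxy to hydroxy on the aromatic ring proves far from neutral: it gives a 32-fold higher number from compound 2 to compound 3 (1.51 log units; beyond the scatter), so the methyl on this oxygen cannot be given up without a large shift towards weaker inhibition. Set against the 4-methylphenyl group of compound 1, the 3-hydroxyphenyl group on the nitrogen also comes out behind, with a 4.8-fold higher number from compound 1 to compound 3 (0.68 log units; beyond the scatter), which leaves compound 3 last of the three. Nothing available explains why removing this single methyl has so large an effect.

Going by these compounds, it remains open whether an ethoxy group or an amine at the same place would stay close to compound 2 or fall towards compound 3. Also open, on these data alone, is whether methoxy to hydroxy would give a step of similar size with another group in place of the propargyl-bearing sulfur chain.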